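From Methoxy to Fluoro in a Cell Cytotoxicity Test

The compounds below may be only part of what the source reports. "The series", "measured", "known", "first", "only" and "open" are said of these compounds alone.

Measured so far in a functional assay on A549 cells (Homo sapiens) for cytotoxicity, read by MTT assay; a lower number here means a stronger inhibitor, a higher number a weaker inhibitor:
Compound 1 `COC(=O)C[C@H]1C[C@@H](O)[C@@H](C)[C@@H](c2ccc(C(C)C)cc2)N1` gives "not active" (no number reported)
Compound 2 `COC(=O)C[C@H]1C[C@@H](O)[C@@H](C)[C@@H](c2ccc(OC)cc2)N1` gives 23500 nM

Among the measured compounds shown here, compound 2 is the only compound here with a number, because compound 1 is reported as "not active" (no number reported) and offers no figure for comparison. Compound 3 `COC(=O)C[C@H]1C[C@@H](O)[C@@H](C)[C@@H](c2ccc(F)cc2)N1` keeps the shared core and makes one change fluoro in place of methoxy on an aromatic carbon with fluoro in place of methoxy on an aromatic carbon. For the measured compounds named here, no measured step shows what a swap at this place does, so no shift beyond the usual scatter is expected. The estimated step of a 1.2-fold higher number from compound 2 to compound 3 (0.08 log units; within the scatter) is therefore small. Compound 3 is estimated at 28000 nM with 11000 nM to 70000 nM as the expected range.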

Compound 3, half-maximal inhibitory concentration: 26600 nM
The estimate for compound 3 lay 1.1-fold (0.02 log units) above the measured number; the range from low to high includes it.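

Fluoro in place of methoxy gives a 1.1-fold higher number from compound 2 to compound 3 (0.05 log units; within the scatter) in this assay, the first measured swap at this place, on an aromatic carbon of the ring. Methoxy counts one hydrogen-bond acceptor and fluoro none, yet the two numbers cannot be told apart, so this single swap gives no sign that the acceptor matters here. From the compounds shown here alone, whether an amine or a carboxylic acid at this place would move the number beyond the scatter remains open. No measurement shown explains why these two numbers stay so close.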